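The compounds below may be only part of what the source reports. "The series", "measured", "known", "first", "only" and "open" are said of these compounds alone.

Compound 1 `COc1ccc2nc(C)cc(OCC(=O)Nc3cc(C)cc(C)c3)c2c1` and compound 2 `Cc1cc(C)cc(NC(=O)COc2cc(C)nc3ccc(C)cc23)c1` share one core and differ by methoxy in place of methyl on an aromatic carbon. In a toxicity assay on HepG2 cells (Homo sapiens) for inhibition, read by CellTiter-Glo, with a stated time of 48 h (a lower number here means a stronger inhibitor, a higher number a weaker inhibitor), compound 1 gives 20000 nM, while compound 2 gives 15900 nM, a step of a 1.3-fold lower number from compound 1 to compound 2 (0.10 log units; within the scatter). Compound 3 `Cc1cc(C)cc(NC(=O)COc2cc(C)nc3ccc(C(F)(F)F)cc23)c1` is compound 2 with trifluoromethyl in place of methyl on an aromatic carbon. For compound 3 this assay reports only a limit, > 100000 nM, the limit being (the limit of > 100000 nM in this assay, at which 1 of the 3 values shown sits). That change brought an at least 6.2-fold higher number from compound 2 to compound 3 (0.79 log units; beyond the scatter). Compound 4 `COc1ccc2nc(C(F)(F)F)cc(OCC(=O)Nc3cc(C)cc(C)c3)c2c1` is not yet measured and differs from compound 1 by trifluoromethyl in place of methyl on an aromatic carbon. This is the same kind of change as from compound 2 to compound 3, but not the same: there the carbon sat on a six-membered aromatic ring of carbon only, here on a six-membered aromatic ring with 1 nitrogen, next to the ring nitrogen. Resting on an at least 6.2-fold higher number from compound 2 to compound 3 (0.79 log units; beyond the scatter), compound 4 is expected near 60000 nM, between 20000 nM and 200000 nM, which would be an estimated step of a 3.0-fold higher number from compound 1 to compound 4 (0.48 log units; beyond the scatter).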

Compound 4, half-maximal inhibitory concentration: > 100000 nM
Compound 4 gave a limit, no number; the forecaster's own chance of this, stated with the estimate: 40%; at least 1.6-fold (0.22 log units) between middle value and limit.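

In this assay, trifluoromethyl in place of methyl on the core of compound 1 gave an at least 5.0-fold higher number from compound 1 to compound 4 (0.69 log units; beyond the scatter), so the number rises on both cores shown, although the change sits on a different ring in each. For compound 4 this assay reports only a limit, > 100000 nM, and compound 3 sits at the same limit: the limit of > 100000 nM in this assay, at which 2 of the 4 values shown sit. The direction therefore carries from one core to the other, but the size of the step cannot be said to carry with it: the same change on two cores in this assay, an at least 6.2-fold higher number (0.79 log units; beyond the scatter) from compound 2 to compound 3 and an at least 5.0-fold higher number (0.69 log units; beyond the scatter) from compound 1 to compound 4; the limit leaves it open whether they differ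

Still open, as far as these compounds go, is how an amine or a carboxylic acid at that same place would read in this assay. From the compounds shown here alone, the part on the amide side is the same in all four compounds, so its share in these numbers also stays open.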